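This account rests on a few compounds, and the source may have more. Where it says the series, first, only, none or still open, it means among the compounds named here.

In a functional assay on B16-F10 cells (Mus musculus) for antiproliferative activity, read by MTT assay, with a stated time of 48 h; on this read-out higher numbers stand for weaker inhibition and lower numbers for stronger inhibition:

compound 1 `O=C(/C=C/c1ccc(Br)cc1)Nc1cc(-c2ccc(Br)cc2)[nH]n1`: 1280 nM
compound 2 `Cc1ccc(-c2cc(NC(=O)/C=C/c3ccc(C(F)(F)F)cc3)n[nH]2)cc1`: 1210 nM
compound 3 `COc1ccc(/C=C/C(=O)Nc2cc(-c3ccc(C)cc3)[nH]n2)cc1`: 1370 nM
compound 4 `Cc1ccc(-c2cc(NC(=O)/C=C/c3ccc(Br)cc3)n[nH]2)cc1`: not yet measured

Compound 3, at 1370 nM, stands within the scatter of both compound 1 and compound 2, so the three values form one level and give no order. The next step leads to compound 4, with bromo in place of methoxy on an aromatic carbon, 4-methoxyphenyl to 4-bromophenyl: bromo in place of methoxy on an aromatic carbon.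

Going by the values given here, one measured step bears directly on this change: a 1.1-fold higher number from compound 2 to compound 3 (0.05 log units; within the scatter), with methoxy in place of trifluoromethyl on an aromatic carbon. Compound 1 also carries a 4-bromophenyl group and gives 1280 nM, though it differs from compound 3 elsewhere too. Among the compounds with values here, no measured step isolates bromo against methoxy. Nothing beyond the scatter is therefore expected in this assay, and no direction can be assigned. The expected step is a 1.1-fold lower number from compound 3 to compound 4 (0.04 log units; within the scatter). For compound 4 the estimated value is 1250 nM, with an expected range of 800 nM to 1950 nM.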

Compound 4, half-maximal inhibitory concentration: 1570 nM
The estimate for compound 4 lay 1.3-fold (0.10 log units) below the measured number; the measured number falls inside the stated range.
By their numbers in this assay, from the lowest: compounds 2, 1, 3 and 4 (each within the scatter of the next).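

In this assay bromo in place of methoxy gives a 1.1-fold higher number from compound 3 to compound 4 (0.06 log units; within the scatter) and bromo in place of trifluoromethyl gives a 1.3-fold higher number from compound 2 to compound 4 (0.11 log units; within the scatter) so methoxy, trifluoromethyl and bromo, para to a large group, now stand within the scatter of one another in direct one-place comparisons. At a second aromatic carbon, methyl in place of bromo gives a 1.2-fold higher number from compound 1 to compound 4 (0.09 log units; within the scatter) so that single change also leaves the number at the same level. No supporting measurement bears on this flat result.

Open, from the compounds shown here alone, is whether an amine or a carboxylic acid at the first of these places would hold this level or move the number beyond the scatter. Also open, going by these compounds, is whether a change in the shared core, rather than in the groups on its aromatic carbons, would separate these compounds.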